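A few compounds are considered here, and "the series" means these few. Any claim that something is new, unique, unknown or untested is made for them only; others in the source may bear on it.

Of the compounds shown here, three of this shared core have been tested in an ADME assay on cells (Mus musculus) for cytotoxicity, read by MTT assay; a lower number here means that less compound is tolerated, a higher number that more compound is tolerated. Compound 1 `OCc1cn(Cc2cc(C(F)(F)F)cc(C(F)(F)F)c2)nn1` gives > 53400 nM, which is a limit of the assay rather than a number. Compound 2 `N#Cc1cccc(Cn2cc(CCO)nn2)c1` gives > 100000 nM, again only a limit. Compound 3 `Cc1cc(C)cc(Cn2cc(CO)nn2)c1` gives > 100000 nM, also a limit. Compound 2 thus stands at the limit of > 100000 nM in this assay, at which 2 of the 3 values shown sit. The other value sits at the limit of > 53400 nM in this assay, at which 1 of the 3 values shown sits. Compound 4 `CCc1c(CCO)nnn1Cc1cccc(C#N)c1` is not yet measured; it differs from compound 2 by ethyl in place of hydrogen on an aromatic carbon. Within the data shown here, no measured pair shows a change of this kind, so the step from compound 2 to compound 4 in this assay is expected to be none beyond the scatter, a number no higher from compound 2 to compound 4 (the limit leaves the size open), most likely ending again at a limit. Compound 4 is estimated at 100000 nM, with a range from 50000 nM to 200000 nM.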

Compound 4, half-maximal cytotoxic concentration: > 100000 nM
Compound 4 was reported as a limit (the forecaster's own chance of this, stated with the estimate: 75%); the middle value lies on the limit itself.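

Compound 2 and compound 4 are both reported only as limits in this assay, so no step can be read between them. The compounds shown leave open what concentration of any of them harms these cells, and whether ethyl in place of hydrogen changes it.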